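Acetyl in place of hydrogen on the aromatic amine of compound 3

This account rests on a few compounds, and the source may have more. Where it says the series, first, only, none or still open, it means among the compounds named here.

Compound 3 `N#CC1=C(N)Oc2c(c3nc4ccccc4nc3c3ccccc23)C12C(=O)N(Cc1cnnn1-c1ccc(N)cc1)c1ccccc12` shares its core with compound 1 `N#CC1=C(N)Oc2c(c3nc4ccccc4nc3c3ccccc23)C12C(=O)N(Cc1cnnn1-c1ccc(Br)cc1)c1ccccc12` and compound 2 `N#CC1=C(N)Oc2c(c3nc4ccccc4nc3c3ccccc23)C12C(=O)N(Cc1cnnn1-c1ccccc1Br)c1ccccc12`. In a functional assay on MCF7 cells (Homo sapiens) for antiproliferative activity, read by MTT assay, with a stated time of 48 h (a lower number here means a stronger inhibitor, a higher number a weaker inhibitor), compound 1 gives 36600 nM. For compound 2 this assay reports only a limit, > 50000 nM. For compound 3 this assay likewise reports only a limit, > 50000 nM, so compound 3 stands at the limit of > 50000 nM in this assay, at which 2 of the 3 values shown sit. The steps of an at least 1.3-fold higher number from compound 1 to compound 3 (0.13 log units; that floor lies within the scatter) and an at least 1.3-fold higher number from compound 1 to compound 2 (0.13 log units; that floor lies within the scatter) are floors within the scatter, and the step that the two limits leave unreadable from compound 2 to compound 3 cannot be read. Compound 4 `CC(=O)Nc1ccc(-n2nncc2CN2C(=O)C3(C(C#N)=C(N)Oc4c3c3nc5ccccc5nc3c3ccccc43)c3ccccc32)cc1` differs from compound 3 by acetyl in place of hydrogen on a nitrogen on an aromatic ring. For the measured compounds named here, no measured step touches this nitrogen, so the expected step that the limit leaves unreadable from compound 3 to compound 4 is none beyond the scatter. Compound 4 is therefore estimated at 60000 nM, between 25000 nM and 150000 nM, most likely again a limit.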

Compound 4, half-maximal inhibitory concentration: > 50000 nM
Compound 4 was reported as a limit; the forecaster's own chance of this, stated with the estimate: 75%; the middle value lies beyond the limit too.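

In this assay compound 4 gives only a limit, > 50000 nM, so acetyl on this nitrogen yields no readable value. For the compounds shown here, the steps between limits cannot be read, and the only other step is an at least 1.3-fold higher number from compound 1 to compound 4 (0.13 log units; that floor lies within the scatter). With the amino and acetamido forms both unresolved, the series now sits mostly at one ceiling: the limit of > 50000 nM in this assay, at which 3 of the 4 values shown sit.

Going by these compounds, it remains open whether a methyl group or a longer acyl chain on this nitrogen would give a measurable value. A carboxylic acid in place of the amino group is equally unresolved.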